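Methyl on the benzyl ring: expected cytotoxicity of compound 3

The compounds below may be only part of what the source reports. "The series", "measured", "known", "first", "only" and "open" are said of these compounds alone.

Measured so far:
compound 1, `CN1CCN(CC(=O)Nc2ccc(-c3nc(-c4ccccc4)c(-c4ccccc4)n3C)cc2)CC1`: 49.1% in a functional assay on HT-29 cells (Homo sapiens) for cytotoxicity, read by MTT assay, with a stated time of 24 h, tested at 32 ug/mL; on this read-out higher numbers stand for a stronger effect at the one concentration tested and lower numbers for a weaker effect
compound 2, `Cn1c(-c2ccc(NC(=O)CN3CCN(Cc4ccccc4)CC3)cc2)nc(-c2ccccc2)c1-c1ccccc1`: 40% in this assay

Compound 2 gives the lower of the two numbers, with compound 1 nearest to it, a gap that lies within the scatter. Compound 3, `Cc1ccc(CN2CCN(CC(=O)Nc3ccc(-c4nc(-c5ccccc5)c(-c5ccccc5)n4C)cc3)CC2)cc1`, differs from compound 2 by methyl in place of hydrogen on an aromatic carbon. Within the data shown here, the only measured step, a number 9.1 percentage points lower from compound 1 to compound 2 (within the scatter), touched the same benzyl position and stayed within the scatter, so a small methyl addition there is expected to give no step beyond the scatter, that is no change at the digits printed from compound 2 to compound 3 (within the scatter). Compound 3 is therefore estimated at 40%, within a range of 25% to 55%.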

Compound 3, a percentage reported as activity, at one concentration (the size of the read-out at that concentration, not a potency): 42.3%
Compound 3: the middle estimate sits 2.3 percentage points below what was measured; the measured number falls inside the stated range.
By their numbers in this assay, from the lowest: compounds 2, 3 and 1 (each within the scatter of the next).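

In this assay, methyl in place of hydrogen on an aromatic carbon, para to a large group, gives a step within the scatter (a number 2.3 percentage points higher from compound 2 to compound 3 (within the scatter)), so this position tolerates this small group on the benzyl ring without a readable change. Taken together with the chain carbon, 4-methylphenyl in place of hydrogen also stays within the scatter (a number 6.8 percentage points lower from compound 1 to compound 3 (within the scatter)). No measurement offered here explains either result. From the compounds shown here alone, whether a carboxylic acid, an amine or a longer chain on that ring carbon would give a step beyond the scatter stays open.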